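Trifluoromethoxy for trifluoromethyl on the shared core

The source may report more compounds than this note shows. Statements on the series, on what has been measured and on what is new or still open speak of the compounds shown alone.

Compound 1 `Oc1ccccc1-c1cc(-c2ccccc2C(F)(F)F)cc(-c2ccccc2O)n1` in a functional assay on DU-145 cells (Homo sapiens) for inhibition (a higher number here means a weaker inhibitor, a lower number a stronger inhibitor), gives 4770 nM. Compound 2 `Oc1ccccc1-c1cc(-c2ccc(C(F)(F)F)cc2)cc(-c2ccccc2O)n1` differs from compound 1 by 4-(trifluoromethyl)phenyl in place of 2-(trifluoromethyl)phenyl on an aromatic carbon; the step is an at least 10-fold higher number from compound 1 to compound 2 (1.02 log units; beyond the scatter). For compound 2 only a limit of this assay is known, > 50000 nM, which is the limit of > 50000 nM in this assay, at which 1 of the 3 values shown sits. Compound 3 `Oc1ccccc1-c1cc(-c2ccccc2OC(F)(F)F)cc(-c2ccccc2O)n1` differs from compound 1 by trifluoromethoxy in place of trifluoromethyl on an aromatic carbon, and in this assay compound 3 gives 5850 nM, a step of a 1.2-fold higher number from compound 1 to compound 3 (0.09 log units; within the scatter).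

Compound 4 `Oc1ccccc1-c1cc(-c2ccc(OC(F)(F)F)cc2)cc(-c2ccccc2O)n1` is not yet measured. It differs from compound 2 by trifluoromethoxy in place of trifluoromethyl on an aromatic carbon. This is the same kind of change as from compound 1 to compound 3, but the two places are not the same: in that pair the entering group sits ortho to a large group, here it sits para to a large group.

Within the data shown here, the only measured instance of this kind of change, a 1.2-fold higher number from compound 1 to compound 3 (0.09 log units; within the scatter), lies within the scatter, so for compound 4 a small step that the limit leaves unreadable from compound 2 to compound 4 is expected. This expectation rests on compound 2, for which only a limit of this assay is known, > 50000 nM. It rests also on compound 3 giving 5850 nM. Compound 4 is therefore estimated at 60000 nM in this assay, most likely again reported as a limit.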

Compound 4, half-maximal inhibitory concentration: 20300 nM
The estimate for compound 4 lay 3.0-fold (0.47 log units) above the measured number; measured number inside the range.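

In this assay, trifluoromethoxy in place of trifluoromethyl, para to a large group, gives an at least 2.4-fold lower number from compound 2 to compound 4 (0.39 log units; beyond the scatter). Set beside the same change on the core of compound 1, this shows that the step does not carry over at one size from core to core in this series: the same change on two cores in this assay, a 1.2-fold higher number (0.09 log units; within the scatter) from compound 1 to compound 3 and an at least 2.4-fold lower number (0.39 log units; beyond the scatter) from compound 2 to compound 4, at least 3.0-fold (0.48 log units) apart, beyond the scatter of two such steps Compound 2 is known only as a limit, > 50000 nM, so the true size of its step stays unread, and the two pairs give a difference between two cores, not a rule for other cores or a cause for that difference.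

Still open, from the compounds shown here alone, is whether a nitrile, a chlorine or a methyl group at the same place on the core of compound 2 would give a number nearer that of compound 2 or that of compound 4. Also open, going by these compounds, is whether the trifluoromethoxy change would keep either step size on a core carrying a methoxy or an amine in place of a hydroxyl group.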